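The source may hold more compounds than are shown below. What is called first, only, known or untested is meant among the compounds shown, and "the series" means these compounds.

Measured compounds:
compound 1, `CC(C(=O)NCc1ccc(C(F)(F)F)nc1-c1ccccc1F)c1ccc(NS(C)(=O)=O)c(F)c1`: in an assay on CHO cells for antagonist activity at transient receptor potential cation channel subfamily V member 1 (Homo sapiens), read by FLIPR (on this read-out lower numbers stand for stronger inhibition and higher numbers for weaker inhibition), compound 1 gives 63.3 nM
compound 2, `Cc1cc(-c2nc(C(F)(F)F)ccc2CNC(=O)C(C)c2ccc(NS(C)(=O)=O)c(F)c2)ccc1F`: compound 2 gives 0.4 nM
compound 3, `CC(C(=O)NCc1ccc(C(F)(F)F)nc1-c1ccsc1)c1ccc(NS(C)(=O)=O)c(F)c1`: compound 3 gives 2 nM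

Compound 3 stands second highest of the three numbers, with a 5.0-fold higher number from compound 2 to compound 3 (0.70 log units; beyond the scatter) on one side and a 32-fold lower number from compound 1 to compound 3 (1.50 log units; beyond the scatter) on the other. Compound 4, `CC(C(=O)NCc1ccc(C(F)(F)F)nc1-c1ccc2cc[nH]c2c1)c1ccc(NS(C)(=O)=O)c(F)c1`, is not yet measured. Its change from compound 3 is 1H-indol-6-yl in place of thiophen-3-yl on an aromatic carbon. The steps that exchange the group at this place, a 32-fold lower number from compound 1 to compound 3 (1.50 log units; beyond the scatter) and a 160-fold lower number from compound 1 to compound 2 (2.20 log units; beyond the scatter), were both large and in the same direction, while a 5.0-fold higher number from compound 2 to compound 3 (0.70 log units; beyond the scatter) was modest; a modest step lower in this assay, or none beyond the scatter, is therefore expected for compound 4. Compound 4 is estimated at 1 nM, range 0.2 nM to 6 nM, the expected step being a 2.0-fold lower number from compound 3 to compound 4 (0.30 log units; within the scatter).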

Compound 4, inhibition constant: 20.3 nM
Beside the measured number, compound 4's estimate is 20-fold (1.31 log units) below it; measured number above the stated range.
By their numbers in this assay, from the lowest: compound 2; then compound 3; then compound 4; then compound 1.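

In this assay, among these compounds, 1H-indol-6-yl, the only group here at this position with a hydrogen-bond donor, gives a 10-fold higher number from compound 3 to compound 4 (1.01 log units; beyond the scatter) and a 51-fold higher number from compound 2 to compound 4 (1.71 log units; beyond the scatter), yet still a 3.1-fold lower number from compound 1 to compound 4 (0.49 log units; beyond the scatter). Replacing 2-fluorophenyl at this place therefore helps to very different degrees, and a larger aromatic group does not by itself match thiophen-3-yl. No measurement shown accounts for this loss.

From the compounds shown here alone, whether the indole hydrogen or the added ring drives the step stays open. So does how a phenyl ring carrying an aminomethyl or carboxylic acid group would read here.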